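This account rests on a few compounds, and the source may have more. Where it says the series, first, only, none or still open, it means among the compounds named here.

Compound 1 `O=C(Nc1ccc(Oc2ccnc3[nH]ccc23)cc1)c1ccc(-c2ccc(Cl)cc2)cn1` gives > 10000 nM in a functional assay on PC-3 cells (Homo sapiens) for cytotoxicity, read by MTT assay, with a stated time of 72 h (a higher number here means a weaker inhibitor, a lower number a stronger inhibitor), which is a limit of the assay rather than a number. Compound 2 `Cc1ccc(-c2ccc(C(=O)Nc3ccc(Oc4ccnc5[nH]ccc45)cc3)nc2)cc1` likewise sits at a limit, > 10000 nM. The step that the two limits leave unreadable from compound 1 to compound 2 is unreadable, as both values sit at the limit of > 10000 nM in this assay, at which 2 of the 3 values shown sit. Compound 3 `Cc1ccc(-c2ccc(C(=O)Nc3ccc(Oc4ccnc5[nH]ccc45)c(F)c3)nc2)cc1` gives 2640 nM, the only measured number shown, reached through the step of an at least 3.7-fold lower number from compound 2 to compound 3 (0.57 log units; beyond the scatter). Compound 4 `O=C(Nc1ccc(Oc2ccnc3[nH]ccc23)c(F)c1)c1ccc(-c2ccc(F)cc2F)cn1` differs from compound 3 by 2,4-difluorophenyl in place of 4-methylphenyl on an aromatic carbon. Among the compounds with values here, neither measured step tests this change: the one earlier change on that same ring is unreadable, and the readable step concerns a fluoro added on a different ring. No step beyond the scatter is therefore expected in this assay. Compound 4 is expected to give 3000 nM, between 800 nM and 10000 nM. The expected step of a 1.1-fold higher number from compound 3 to compound 4 (0.06 log units; within the scatter) lies within the scatter.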

Compound 4, half-maximal inhibitory concentration: 4720 nM
Estimate against measurement, compound 4: 1.6-fold (0.20 log units) below, and the stated range covers the measured number.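

In this assay, 2,4-difluorophenyl in place of 4-methylphenyl gives a 1.8-fold higher number from compound 3 to compound 4 (0.25 log units; within the scatter), so these two groups cannot be told apart at this position. This is the first readable step on this ring, since the earlier swap of methyl for chloro stayed unreadable, with compound 1 and compound 2 both at a limit of the assay: the limit of > 10000 nM in this assay, at which 2 of the 4 values shown sit.

On these data alone, what remains open is whether any group at this position would give a step beyond the scatter. A phenyl ring carrying an amine or a carboxylic acid, or a longer chain in place of the ring, could test that.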